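This account rests on a few compounds, and the source may have more. Where it says the series, first, only, none or still open, it means among the compounds named here.

The measured compounds:
Compound 1 `COc1cccc(C(=O)Nc2ccc(Cl)cc2CN2C(=O)c3ccccc3C2=O)c1` gives < 1000 nM in an assay on CHO cells for positive allosteric modulation of metabotropic glutamate receptor 5 (Rattus norvegicus), read by FLIPR; a lower number here means that less compound is needed, a higher number that more compound is needed for the effect.
Compound 2 `O=C(Nc1ccc(Cl)cc1CN1C(=O)c2ccccc2C1=O)c1cccnc1` gives < 1000 nM in this assay.
Compound 3 `O=C(Nc1ccc(Cl)cc1CN1C(=O)c2ccccc2C1=O)c1ncccn1` gives < 1000 nM in this assay.

Each of these three values is a limit of the assay rather than a number. Compound 3 therefore stands only at a limit, and the two other values shown are limits as well. Because all three values sit at the limit of < 1000 nM in this assay, at which 3 of the 3 values shown sit, none of the steps between them can be sized: a step that the two limits leave unreadable from compound 1 to compound 2, a step that the two limits leave unreadable from compound 1 to compound 3 and a step that the two limits leave unreadable from compound 2 to compound 3 all remain unreadable.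

Compound 4 `COc1ccccc1C(=O)Nc1ccc(Cl)cc1CN1C(=O)c2ccccc2C1=O` has not yet been measured in this assay. It differs from compound 3 by 2-methoxyphenyl in place of pyrimidin-2-yl on a carbonyl carbon. All three measured steps are exchanges of the aromatic group on this same carbonyl carbon, so they are the ones that bear on the change, but each is unreadable in size, and no direction or size of step can be drawn from them. What they do show is that three different groups at this position all keep the value under the limit, which suggests compound 4 will stay in the same region. On that basis the resulting step is expected to be a step that the limit leaves unreadable from compound 3 to compound 4. Compound 4 is estimated at 300 nM, with a range from 40 nM to 2000 nM, and a considerable chance that the assay again reports only a limit.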

Compound 4, half-maximal effective concentration: < 1000 nM
Compound 4: only a limit was reported (the forecaster's own chance of this, stated with the estimate: 65%); the middle value lies beyond the limit too.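

In this assay compound 4 gives < 1000 nM as a limit and not a number. No step from compound 1, compound 2 or compound 3 to compound 4 can be read, because all the values sit at one limit: the limit of < 1000 nM in this assay, at which 4 of the 4 values shown sit.

The compounds shown leave open how far apart these four compounds truly lie, and whether exchanging the aromatic group on the carbonyl carbon changes the value at all.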